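Carbamate to thionocarbamate change on a piperidine nitrogen

This account rests on a few compounds, and the source may have more. Where it says the series, first, only, none or still open, it means among the compounds named here.

Of the compounds shown here, three sharing one core have been measured in a functional assay on isolated protein for inhibition of Glucose-dependent insulinotropic receptor (Rattus norvegicus), read by HTRF and cAMP accumulation; on this read-out higher numbers stand for an effect only at larger amounts of compound and lower numbers for an effect already at smaller amounts. Compound 1 `Cc1nc(S(C)(=O)=O)ccc1Oc1ncnc(OC2CCN(C(=O)OC(C)F)CC2)c1F` gives 315 nM and stands second highest of the three numbers: compound 2 `Cc1nc(S(C)(=O)=O)ccc1Oc1ncnc(OC2CCN(C(=O)SC(C)(C)C)CC2)c1F` gives 30.7 nM, and compound 3 `Cc1nc(S(C)(=O)=O)ccc1Oc1ncnc(OC2CCN(C(=S)OC(C)C)CC2)c1F` gives 1050 nM. Compound 4 `Cc1nc(S(C)(=O)=O)ccc1Oc1ncnc(OC2CCN(C(=S)OC3(C)CC3)CC2)c1F` is not yet measured; it differs from compound 1 by a group of 7 heavy atoms (5 carbon, 1 oxygen, 1 sulfur; one three-membered non-aromatic ring of carbon only) in place of a group of 6 heavy atoms (3 carbon, 2 oxygen, 1 fluorine; no ring), on an amine nitrogen in a ring.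

Within the data shown here, the nearest measured step is the one from compound 1 to compound 3, where a thiocarbonyl with an isopropyl group replaces the fluoroethyl carbamate: a 3.3-fold higher number from compound 1 to compound 3 (0.52 log units; beyond the scatter). Compound 4 carries the same thiocarbonyl, with a 1-methylcyclopropyl group on the oxygen in place of isopropyl. The step of a 34-fold higher number from compound 2 to compound 3 (1.53 log units; beyond the scatter) shows that the thiocarbonyl series sits well above the thioester of compound 2, while a 10-fold lower number from compound 1 to compound 2 (1.01 log units; beyond the scatter) shows the large gain available at this position. He therefore expects compound 4 to land near compound 3, with a modest rise from compound 1, a 1.9-fold higher number from compound 1 to compound 4 (0.28 log units; within the scatter). His estimate for compound 4 in this assay is 600 nM, within 150 nM to 2500 nM.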

Compound 4, half-maximal effective concentration: 48.8 nM
Beside the measured number, compound 4's estimate is 12-fold (1.09 log units) above it; the whole stated range lies above it.
By their numbers in this assay, from the lowest: compounds 2 and 4 (each within the scatter of the next); then compound 1; then compound 3.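

In this assay, the thiocarbonyl alone does not fix a high number at this position: changing only the group on its oxygen gives a 22-fold lower number from compound 3 to compound 4 (1.33 log units; beyond the scatter), so that group accounts for a large difference. The same thiocarbonyl can also lie on the lower side of the group in compound 1, with a 6.5-fold lower number from compound 1 to compound 4 (0.81 log units; beyond the scatter), the opposite direction to the step seen with compound 3. The thioester and the 1-methylcyclopropyl thiocarbonyl cannot be told apart, with a 1.6-fold higher number from compound 2 to compound 4 (0.20 log units; within the scatter), so two different groups on the amine nitrogen reach numbers within the scatter of each other.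

No evidence is available on what lies behind the gain from isopropyl to 1-methylcyclopropyl. On these data alone, whether a cyclobutyl or an unsubstituted cyclopropyl group on the same oxygen would give a low number remains open.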